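Hydrazone aryl replacement on the shared core

The source may report more compounds than this note shows. Statements on the series, on what has been measured and on what is new or still open speak of the compounds shown alone.

Among the compounds with values here, compound 3 `CN(C)CCn1cnnc1-c1cc(Oc2ccc(NC(=O)N/N=C/c3ccc(F)cc3)cc2F)ccn1` gives 1370 nM in a functional assay on HT-29 cells (Homo sapiens) for cytotoxicity, read by MTT assay, with a stated time of 72 h (a lower number here means a stronger inhibitor, a higher number a weaker inhibitor), and stands second highest of the three numbers measured so far. Its nearest neighbour is compound 1 `CN(C)CCn1cnnc1-c1cc(Oc2ccc(NC(=O)N/N=C/c3c[nH]c4ccccc34)cc2F)ccn1` with 1300 nM; the furthest is compound 2 `Cn1ncnc1-c1cc(Oc2ccc(NC(=O)N/N=C/c3ccccc3)cc2F)ccn1` with 30200 nM. Compound 4 `COc1ccc(/C=N/NC(=O)Nc2ccc(Oc3ccnc(-c4nncn4CCN(C)C)c3)c(F)c2)cc1O` is not yet measured; its change from compound 3 is 3-hydroxy-4-methoxyphenyl in place of 4-fluorophenyl on a carbon with a double bond to nitrogen. Within the data shown here, one measured step touches the same carbon: a 1.1-fold higher number from compound 1 to compound 3 (0.02 log units; within the scatter), which left the number unchanged within the scatter. Among the measured compounds shown here, no measured compound carries the 3-hydroxy-4-methoxyphenyl group, so the expectation rests on that single flat step alone. The step of a 1.1-fold higher number from compound 3 to compound 4 (0.04 log units; within the scatter) is therefore expected to be small, with no clear direction. For compound 4 the estimate in this assay is 1500 nM, within a range of 500 nM to 5000 nM.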

Compound 4, half-maximal inhibitory concentration: 960 nM
Compound 4: middle estimate off by 1.6-fold (0.19 log units), on the high side, and the stated range covers the measured number.
By their numbers in this assay, from the lowest: compounds 4, 1 and 3 (each within the scatter of the next); then compound 2.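

On the carbon with a double bond to nitrogen, the 3-hydroxy-4-methoxyphenyl group gives a 1.4-fold lower number from compound 3 to compound 4 (0.15 log units; within the scatter) and a 1.4-fold lower number from compound 1 to compound 4 (0.13 log units; within the scatter) in this assay. Within the data shown here, three different aromatic groups at this place, including one carrying both hydroxy and methoxy substituents, therefore remain within the scatter of one another, which extends the single flat step seen before. No supporting evidence bears on this flatness. Still open, going by these compounds, is whether this flatness holds for a group without an aromatic ring, such as cyclohexyl, or for a phenyl ring carrying an amine or a carboxylic acid.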